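The source may hold more compounds than are shown below. What is called first, only, known or untested is meant among the compounds shown, and "the series" means these compounds.

Measured compounds:
- compound 1, `Cc1nc(N)c2nc(O)n(Cc3ccccc3)c2n1`: 1 uM
- compound 2, `CCSc1nc(N)c2nc(O)n(Cc3ccccc3)c2n1`: 0.1 uM
- compound 3, `Nc1ncnc2c1nc(O)n2Cc1ccccc1`: 10 uM

In a functional assay (spleen, spleen) for activation, with Mus musculus as the target (a lower number here means that less compound is needed, a higher number that more compound is needed for the effect), compound 3 gives the highest of the three numbers; compound 1 is nearer to it and compound 2 furthest from it. Compound 4, `Nc1nc(S)nc2c1nc(O)n2Cc1ccccc1`, is obtained from compound 3 by the change (sulfanyl in place of hydrogen on an aromatic carbon). Going by the values given here, two measured steps bear on this position: a 10-fold higher number from compound 1 to compound 3 (1.00 log units; beyond the scatter) and a 100-fold higher number from compound 2 to compound 3 (2.00 log units; beyond the scatter), so putting a group of one heavy atom or an ethylsulfanyl group at this aromatic carbon in place of hydrogen went with a lower number each time. A sulfanyl group is smaller than ethylsulfanyl, so a step of modest size toward a lower number is expected for compound 4, a 10-fold lower number from compound 3 to compound 4 (1.00 log units; beyond the scatter). In this assay compound 4 is estimated at 1 uM, with a range from 0.2 uM to 5 uM.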

Compound 4, minimum effective concentration: 10 uM
The estimate for compound 4 lay 10-fold (1.00 log units) below the measured number, and the stated range ends below it.
By their numbers in this assay, from the lowest: compound 2; then compound 1; then compounds 3 and 4 (each within the scatter of the next).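

In this assay, sulfanyl on this aromatic carbon between two ring nitrogen atoms gives no gain over hydrogen (no change at the digits printed from compound 3 to compound 4 (within the scatter)), so sulfur alone does not produce the lower numbers seen earlier. Removing the ethyl from the sulfur costs a large step (a 100-fold higher number from compound 2 to compound 4 (2.00 log units; beyond the scatter)), and sulfanyl also falls short of methyl (a 10-fold higher number from compound 1 to compound 4 (1.00 log units; beyond the scatter)). No available evidence explains these steps.

Open, from the compounds shown here alone, is whether methylsulfanyl or a longer chain on the sulfur, such as butylsulfanyl, would match ethylsulfanyl. Also open, going by these compounds, is where an amine at this carbon would fall.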